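From Isopropoxy to Tert-Butoxy: A One-Methyl Step

The source may hold more compounds than are shown below. What is called first, only, known or untested is meant among the compounds shown, and "the series" means these compounds.

For the measured compounds named here, in an ADME assay on microsomes from liver (Homo sapiens) for metabolic stability, with a stated time of 60 min, tested at 1 uM (a higher number here means that more of the compound is left, a lower number that less of the compound is left), compound 3 (`COc1cn2ncc(-c3ccnc(OC(C)C)c3)c2nc1-c1cnn(C)c1`) gives 32%, the lowest of the three numbers measured so far. Compound 1 (`COc1cc(-c2cnn3cc(OC)c(C)nc23)ccn1`) gives 44%, and compound 2 (`Cn1cc(-c2nc3c(-c4ccnc(OC5CC5)c4)cnn3cc2OCCCC(C)(C)O)cn1`) gives 54%. Both of these lie above compound 3 by more than the usual scatter, but each differs from it in more than one place, so neither gap reveals what a single small change would do.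

The next compound, compound 4 (`COc1cn2ncc(-c3ccnc(OC(C)(C)C)c3)c2nc1-c1cnn(C)c1`), changes compound 3 in just one place: methyl in place of hydrogen on a saturated chain carbon bound to an oxygen on an aromatic ring and two saturated chain carbons. In plain terms, isopropoxy becomes tert-butoxy. Going by the values given here, no measured pair here shows the effect of a change like this, so the expectation is necessarily rough. The expected result is little or no change beyond the scatter in this assay, with a slight lean downward: the estimated move is a number 2 percentage points lower from compound 3 to compound 4 (within the scatter). For compound 4, the estimate is 30%, with an expected range of 14% to 48%.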

Compound 4, percent of the compound remaining: 35%
Beside the measured number, compound 4's estimate is 5 percentage points below it, within the range that was stated.
By their numbers in this assay, from the lowest: compounds 3, 4, 1 and 2 (each within the scatter of the next, the first and the last beyond it).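

For the compounds shown here, this is the first pair here that differs in one place, so it gives the first direct reading of a single change: methyl in place of hydrogen on a saturated chain carbon bound to an oxygen on an aromatic ring and two saturated chain carbons. In this assay, isopropoxy to tert-butoxy gives a number 3 percentage points higher from compound 3 to compound 4 (within the scatter), so this one-methyl step on the shared core does not separate the two compounds. Nothing shown here explains this result.

From the compounds shown here alone, whether a larger change at this place, such as an amine or a longer chain in place of the tert-butoxy group, would move the number beyond the scatter remains open. So does whether the same methyl step would behave alike on a different core.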